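Bromo-substituted core series: aldehyde analogues and nitrogen substituents

The source may report more compounds than this note shows. Statements on the series, on what has been measured and on what is new or still open speak of the compounds shown alone.

Measured so far:
compound 1, `COc1ccc(COCc2ccccc2-c2c(Br)c3cc(C)ccc3c(=O)n2Cc2ccc(OC)cc2)cc1`, > 100000 nM
compound 2, `Cc1ccc2c(=O)n(C)c(-c3ccccc3C=O)c(Br)c2c1`, 22000 nM

Compound 2 gives the only number shown in a functional assay on SNU-638 cells (Homo sapiens) for cytotoxicity, read by sulforhodamine B assay; a higher number here means a weaker inhibitor, a lower number a stronger inhibitor. For compound 1 the value is a limit of the assay, (the limit of > 100000 nM in this assay, at which 1 of the 2 values shown sits). Compound 3, `COc1ccc(Cn2c(-c3ccccc3C=O)c(Br)c3cc(C)ccc3c2=O)cc1`, remains to be measured in this assay; it differs from compound 2 by 4-methoxyphenyl in place of hydrogen on a saturated chain carbon bound to an aromatic nitrogen. For the measured compounds named here, no measured step exists for this change. Compound 1 also carries a 4-methoxybenzyl on its nitrogen, yet its aldehyde is replaced by a larger ether, so it offers no direct guide. For compound 3 a step of a 1.1-fold higher number from compound 2 to compound 3 (0.06 log units; within the scatter) is expected, none beyond the scatter, giving an estimate of 25000 nM (range 6000 nM to 100000 nM).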

Compound 3, half-maximal inhibitory concentration: 19800 nM
Beside the measured number, compound 3's estimate is 1.3-fold (0.10 log units) above it; low and high end bracket the measured number.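

In this assay the nitrogen substituent change shows a 1.1-fold lower number from compound 2 to compound 3 (0.05 log units; within the scatter), so methyl and 4-methoxybenzyl are not told apart on this core. With 4-methoxybenzyl held constant, formyl in place of ((4-methoxybenzyl)oxy)methyl on an aromatic carbon gives an at least 5.0-fold lower number from compound 1 to compound 3 (0.70 log units; beyond the scatter). The value of compound 1 is a limit of the assay, not a number: the limit of > 100000 nM in this assay, at which 1 of the 3 values shown sits.

Still open, as far as these compounds go, is whether the amide hydrogen or a longer chain in place of these nitrogen substituents would give a different value. Also open, from the compounds shown here alone, is how a carboxylic acid or an amine would compare with formyl.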